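Adding a methyl to the carbamoyl phenyl of compound 2

The source may report more compounds than this note shows. Statements on the series, on what has been measured and on what is new or still open speak of the compounds shown alone.

Measured so far in a functional assay on RPMI18226 cells (Homo sapiens) for antiproliferative activity, read by sulforhodamine B assay, with a stated time of 48 h, tested at 10 uM; a higher number here means more inhibition at the concentration tested (going by the name of the read-out), a lower number less inhibition:
Compound 1, `O=C(Nc1ccccc1)c1c(-c2ccc(Cl)cc2)cc(-c2ccccc2)nc1Nc1ccccc1`, gives 15%.
Compound 2, `COc1ccc(Nc2nc(-c3ccccc3)cc(-c3ccc(Cl)cc3)c2C(=O)Nc2ccccc2)cc1`, gives 30%.

Going by the values given here, compound 2 stands highest of the two numbers measured so far; the nearest is compound 1, and the only measured step, a number 15 percentage points higher from compound 1 to compound 2 (beyond the scatter), came with methoxy in place of hydrogen on an aromatic carbon of the anilino ring. Compound 3, `COc1ccc(Nc2nc(-c3ccccc3)cc(-c3ccc(Cl)cc3)c2C(=O)Nc2ccc(C)cc2)cc1`, differs from compound 2 by methyl in place of hydrogen on an aromatic carbon. Among the compounds with values here, no measured step touches this position: the step from compound 1 to compound 2 concerns another ring and another group, so it bears on compound 3 only as a hint that a small addition on a peripheral aromatic ring can move this assay modestly. Within the data shown here, with no direct precedent, the step is expected to stay within the scatter, a number 2 percentage points higher from compound 2 to compound 3 (within the scatter). Compound 3 is therefore estimated at 32%, with a range from 15% to 50%.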

Compound 3, a percentage reported as inhibition, at one concentration (the size of the read-out at that concentration, not a potency): 79%
Compound 3: middle estimate off by 47 percentage points, on the low side, and the stated range ends below it.
By their numbers in this assay, from the lowest: compound 1; then compound 2; then compound 3.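

In this assay the phenylcarbamoyl ring proves to be a sensitive position: the change from phenylcarbamoyl to (4-methylphenyl)carbamoyl gives a number 49 percentage points higher from compound 2 to compound 3 (beyond the scatter) and is a large step. Going by these compounds alone, the only earlier step, a number 15 percentage points higher from compound 1 to compound 2 (beyond the scatter), was modest and came with methoxy on the other anilino ring, so it showed nothing about this ring or about how far a methyl here could move the read-out. No measurement at hand explains why this methyl has so large an effect.

From the compounds shown here alone, it remains open whether the gain is specific to methyl or would also come with an ethyl, a longer chain, an amine or a carboxylic acid at the same place. Going by these compounds, it is also open whether the methyl would give a similar step without the methoxy of compound 2, as on compound 1.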